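One Benzyl Swap, One Open Measurement

The source may hold more compounds than are shown below. What is called first, only, known or untested is meant among the compounds shown, and "the series" means these compounds.

- compound 1 `COc1cc(CNc2ncnc3c2ncn3[C@@H]2O[C@H](CO)[C@@H](O)[C@H]2O)cc(OC)c1`: 20200 nM
- compound 2 `OC[C@H]1O[C@@H](n2cnc3c(NCc4ccc(F)cc4F)ncnc32)[C@H](O)[C@@H]1O`: 3400 nM

In a functional assay on HL-60 cells (Homo sapiens) for antiproliferative activity, with a stated time of 72 h (on this read-out higher numbers stand for weaker inhibition and lower numbers for stronger inhibition), compound 2 holds the lower of the two numbers, at 3400 nM. Compound 3 `OC[C@H]1O[C@@H](n2cnc3c(NCc4ccc(F)c(Cl)c4)ncnc32)[C@H](O)[C@@H]1O` carries 3-chloro-4-fluorophenyl in place of 2,4-difluorophenyl on a saturated chain carbon bound to a nitrogen on an aromatic ring. For the measured compounds named here, the only measured step at this place is a 5.9-fold lower number from compound 1 to compound 2 (0.77 log units; beyond the scatter). That single modest step gives no direction for the new group, so no step beyond the scatter is expected in this assay. The estimated change is a 1.1-fold lower number from compound 2 to compound 3 (0.05 log units; within the scatter). Compound 3 is expected at 3000 nM, with an estimated range of 1000 nM to 9000 nM.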

Compound 3, half-maximal inhibitory concentration: 3500 nM
The estimate for compound 3 lay 1.2-fold (0.07 log units) below the measured number, within the range that was stated.
By their numbers in this assay, from the lowest: compounds 2 and 3 (each within the scatter of the next); then compound 1.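

In this assay, exchanging one halogenated phenyl group for another at this place leaves the number level, a 1.0-fold higher number from compound 2 to compound 3 (0.01 log units; within the scatter). The step from the dimethoxy compound is a 5.8-fold lower number from compound 1 to compound 3 (0.76 log units; beyond the scatter), so 3-chloro-4-fluorophenyl and 2,4-difluorophenyl, two different patterns of halogens, both stand apart from 3,5-dimethoxyphenyl. Nothing available explains this result. The compounds shown leave open whether an unsubstituted phenyl group, or a phenyl group carrying an amine, would hold the same level. They also leave open what a longer chain between the nitrogen and the ring would do.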